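Tail replacement from compound 2 to compound 3

The source may hold more compounds than are shown below. What is called first, only, known or untested is meant among the compounds shown, and "the series" means these compounds.

Compound 1 `Cc1cc2c(cc1Cc1ccc(C(=O)NCC3CCCCC3)o1)C(C)(C)CCC2(C)C` carries a cyclohexylmethyl amide and in an assay on isolated protein for binding affinity to Gonadotropin-releasing hormone receptor (Homo sapiens) (a lower number here means a stronger inhibitor, a higher number a weaker inhibitor), compound 1 gives 180 nM. Compound 2 `Cc1cc2c(cc1Cc1ccc(C(=O)NCC3CCCC(CN)C3)o1)C(C)(C)CCC2(C)C` differs by an aminomethyl in place of hydrogen on a saturated ring carbon, and in this assay compound 2 gives 174 nM. The step of a 1.0-fold lower number from compound 1 to compound 2 (0.01 log units; within the scatter) shows that this addition left the number unchanged; compound 2 and compound 1 thus stand together, neither separable from the other.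

Compound 3 `Cc1cc2c(cc1Cc1ccc(C(=O)NCC3CCN(C(=N)N)CC3)o1)C(C)(C)CCC2(C)C` replaces the whole tail: a group of 9 heavy atoms (6 carbon, 3 nitrogen; one six-membered non-aromatic ring with 1 hetero atom) in place of a group of 8 heavy atoms (7 carbon, 1 nitrogen; one six-membered non-aromatic ring of carbon only), on a saturated chain carbon bound to an amide-type nitrogen. Within the data shown here, no measured step covers this exchange. Among the measured compounds shown here, the only step in hand, a 1.0-fold lower number from compound 1 to compound 2 (0.01 log units; within the scatter), concerns a smaller change at the same tail and was within the scatter, so the tail appears tolerant of added nitrogen there. On that basis the step of a 1.0-fold higher number from compound 2 to compound 3 (0.01 log units; within the scatter) is expected to be small, with no direction beyond the scatter asserted. Compound 3 is therefore estimated at 180 nM, within 60 nM to 550 nM.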

Compound 3, inhibition constant: 220 nM
Compound 3: middle estimate off by 1.2-fold (0.09 log units), on the low side; the range from low to high includes it.
By their numbers in this assay, from the lowest: compounds 2, 1 and 3 (each within the scatter of the next).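

The step of a 1.3-fold higher number from compound 2 to compound 3 (0.10 log units; within the scatter) and the step of a 1.2-fold higher number from compound 1 to compound 3 (0.09 log units; within the scatter) in this assay extend the earlier finding from one added aminomethyl to an exchange of the whole tail. On a saturated chain carbon bound to an amide-type nitrogen, a six-membered non-aromatic ring with 1 hetero atom and a double bond outside aromatic rings can thus replace either ring of carbon only without separating from it. The three tails shown remain indistinguishable in this measurement, so none can be ranked above another. No evidence available here accounts for this result. As far as these compounds go, it remains open whether any tail at this place moves the number beyond the scatter, for example a carboxylic acid on the ring or a longer chain carrying the ring.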